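Azetidine Replacing an Anilino Group on a Shared Core

The source may hold more compounds than are shown below. What is called first, only, known or untested is meant among the compounds shown, and "the series" means these compounds.

Of the compounds shown here, three on a shared core have been measured in a functional assay on ECa-109 cells for inhibition, with ECa-109 cell line (Homo sapiens) as the target, read by sulforhodamine B assay; on this read-out higher numbers stand for weaker inhibition and lower numbers for stronger inhibition. Compound 1 `CCc1ccc(NC2=CC(=O)c3nc4n(c3C2=O)[C@H]2OC[C@@H](O)[C@H]2OC4)cc1` gives 3080 nM in this assay. Compound 2 `O=C1C=C(Nc2cccc(Cl)c2)C(=O)c2c1nc1n2[C@H]2OC[C@@H](O)[C@H]2OC1` gives 4690 nM. For compound 3 `COc1ccccc1NC1=CC(=O)c2nc3n(c2C1=O)[C@H]1OC[C@@H](O)[C@H]1OC3` the assay returns only a limit, > 4000 nM. Compound 3 therefore stands at the limit of > 4000 nM in this assay, at which 1 of the 3 values shown sits, and its exact place among the numbers shown cannot be fixed.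

The measured steps all exchange one aryl group on the amine nitrogen for another. The step of a 1.5-fold higher number from compound 1 to compound 2 (0.18 log units; within the scatter) and the step of an at least 1.2-fold higher number from compound 1 to compound 3 (0.11 log units; that floor lies within the scatter) give no movement beyond the scatter, and the step that the limit leaves unreadable from compound 2 to compound 3 cannot be read at all. Across these three aryl variations the numbers stay in the same weak region.

Compound 4 `O=C1C=C(N2CCC2)C(=O)c2c1nc1n2[C@H]2OC[C@@H](O)[C@H]2OC1` differs from compound 3 in that (azetidin-1-yl in place of (2-methoxyphenyl)amino on a double-bonded ring carbon). For the measured compounds named here, no measured step exchanges the aryl amine for a small saturated ring, so the aryl swaps are the only steps that bear on this change, and they were flat or unreadable. The step that the limit leaves unreadable from compound 3 to compound 4 is therefore expected to be small, with a fair chance that the assay again returns only a limit. Compound 4 is estimated at 6000 nM, with a range from 2500 nM to 15000 nM.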

Compound 4, half-maximal inhibitory concentration: > 16000 nM
Compound 4 was reported as a limit; the forecaster's own chance of this, stated with the estimate: 55%; at least 2.6-fold (0.42 log units) between middle value and limit.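

In this assay compound 4 is reported only as a limit, not as a number: the limit of > 16000 nM in this assay, at which 1 of the 4 values shown sits. Exchanging an arylamino group for azetidin-1-yl on this double-bonded ring carbon gives an at least 3.4-fold higher number from compound 2 to compound 4 (0.53 log units; beyond the scatter) and an at least 5.1-fold higher number from compound 1 to compound 4 (0.71 log units; beyond the scatter), so the position that stayed flat under the aryl swaps among compounds 1 and 2 does respond to this larger change, with inhibition weakening in both readable steps. The step involving compound 3 goes no way towards confirming or opposing this, as it cannot be read, and compound 3 is itself reported only as a limit: the limit of > 4000 nM in this assay, at which 1 of the 4 values shown sits.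

The compounds shown leave open which part of the exchange matters, whether it is the loss of the six-membered aromatic ring, the loss of the hydrogen-bond donor on the amine nitrogen, or the change from the larger group to the smaller one, and they do not fix how far compound 4 lies past its limit. On these data alone, a cyclobutylamino group on the same carbon, which keeps that nitrogen hydrogen without the aromatic ring, or a piperidin-1-yl ring, would bear on these questions, and how either would read remains unknown.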